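Amide substituent swap in the antiproliferative series

The source may report more compounds than this note shows. Statements on the series, on what has been measured and on what is new or still open speak of the compounds shown alone.

Three compounds have numbers in a functional assay on HeLa cells (Homo sapiens) for antiproliferative activity, read by CCK-8 assay, with a stated time of 72 h; a lower number here means a stronger inhibitor of growth, a higher number a weaker inhibitor of growth. Compound 2 `CC[C@@H]1C(=O)N(C)c2cnc(-n3ccc4cc(C(=O)NC(C)C)ccc43)nc2N1C1CCCC1` gives 292 nM, the lowest number of the three, and its steps to the other two are beyond the scatter, so it is the strongest inhibitor of growth seen here. Compound 1 `CCCCNS(=O)(=O)c1ccc(Nc2ncc3c(n2)N(c2ccn(C)n2)C(CC)C(=O)N3C)cc1` gives 4320 nM and compound 3 `CCCCNC(=O)c1ccc2c(ccn2-c2ncc3c(n2)N(c2ccn(C)n2)C(CC)C(=O)N3C)c1` gives 4260 nM; both stand roughly equally far from compound 2. Within the data shown here, compound 1 and compound 3 differ from compound 2 in more than one place, so no single step between them can be read.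

Compound 4 `CCCCNC(=O)c1ccc2c(ccn2-c2ncc3c(n2)N(C2CCCC2)[C@H](CC)C(=O)N3C)c1` is not yet measured. It differs from compound 2 in one place only: butyl in place of isopropyl on an amide-type nitrogen. The change is a small one on a chain with no ring and no donors or acceptors gained or lost, and the shared core and its other substituents are kept. Compound 3 carries the butylcarbamoyl already. Its other differences from compound 2 are not isolated, however. In this assay compound 3 gives 4260 nM, and that number cannot be attributed to the butyl alone. The expected step from compound 2 to compound 4 in this assay is therefore small, a 1.4-fold higher number from compound 2 to compound 4 (0.16 log units; within the scatter), likely within or barely beyond the scatter and in no firm direction. Compound 4 is estimated at 420 nM, with a range of 150 nM to 1200 nM.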

Compound 4, concentration for 50% growth inhibition: 346 nM
Estimate against measurement, compound 4: 1.2-fold (0.08 log units) above, and the stated range covers the measured number.
By their numbers in this assay, from the lowest: compounds 2 and 4 (each within the scatter of the next); then compounds 3 and 1 (each within the scatter of the next).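

In this assay, among these compounds, butyl in place of isopropyl on the amide-type nitrogen gives a 1.2-fold higher number from compound 2 to compound 4 (0.07 log units; within the scatter), so at this position, with the rest of the structure held, the two chains cannot be told apart, and the isopropylcarbamoyl to butylcarbamoyl change gives the first single-place reading. Compound 3, which carries the same butylcarbamoyl, gives 4260 nM, but it differs from compound 4 in more than one place, so that pair cannot be read as a step, and neither can any pair involving compound 1. Nothing on hand offers an explanation for the size of this step.

On these data alone, the reading covers only these two small carbon chains on this nitrogen, so it remains open whether a longer chain such as octyl, a chain ending in an amine or a carboxylic acid, or the plain amide carrying only hydrogen would stay within the same range. As far as these compounds go, it also remains open whether the butyl and isopropyl chains would still match on the shared core as it stands in compound 3.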